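The source may report more compounds than this note shows. Statements on the series, on what has been measured and on what is new or still open speak of the compounds shown alone.

Within the data shown here, in a functional assay on Jurkat cells (Homo sapiens) for activation, with a stated time of 24 h (a lower number here means that less compound is needed, a higher number that more compound is needed for the effect), compound 2 `Oc1ccccc1CNc1ccc(-c2ccccc2F)cc1` gives 2150 nM; this is the only number in hand, since compound 1 `COc1ccc(CNc2ccc(C3CCCCC3)cc2)c(O)c1` is recorded only as "not active" (no number reported). Compound 3 `Oc1ccccc1CNc1ccc(C2CCCCC2)cc1` awaits measurement. It differs from compound 2 by cyclohexyl in place of 2-fluorophenyl on an aromatic carbon. Among the measured compounds shown here, no measured pair isolates this change, so the size of the step can only be guessed. For the measured compounds named here, the one hint is that compound 1, which also carries a cyclohexyl, is recorded as "not active" (no number reported). Compound 3 is therefore expected to need more compound than compound 2, by a step of about a 2.8-fold higher number from compound 2 to compound 3 (0.45 log units; beyond the scatter), with an estimated value of 6000 nM in a range from 2000 nM to 20000 nM.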

Compound 3, half-maximal effective concentration: 8800 nM
For compound 3 the middle estimate is 1.5-fold (0.17 log units) below the measured one, and the stated range covers the measured number.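

Among these compounds, putting cyclohexyl in place of 2-fluorophenyl on this aromatic carbon gives a 4.1-fold higher number from compound 2 to compound 3 (0.61 log units; beyond the scatter) in this assay, the first direct comparison at this position, and it favours the 2-fluorophenyl compound. Compound 3 still gives a number, so a non-aromatic ring of carbon here does not abolish the effect. Nothing at hand explains the direction of this step. The change removes the fluorine and the aromatic ring together, and the compounds shown cannot separate the two. On these data alone, how a plain phenyl or a ring carrying an amine would behave here remains open.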